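Amino on the Ring Nitrogen of a Thione Core

This account rests on a few compounds, and the source may have more. Where it says the series, first, only, none or still open, it means among the compounds named here.

Compound 1 `Cc1ccc(-c2nc3ccc(Cl)cc3c(=S)[nH]2)cc1` stands at the lowest number of the two measured: in a functional assay on HeLa cells (Homo sapiens) for antiproliferative activity, read by MTT assay, with a stated time of 48 h (a lower number here means a stronger inhibitor, a higher number a weaker inhibitor), compound 1 gives 4.57 ug/mL. Compound 2 `Cc1ccc(-c2nc3ccc(Cl)cc3c(=O)n2N)cc1` gives 12.1 ug/mL in this assay, a higher number that lies beyond the scatter. Compound 3 `Cc1ccc(-c2nc3ccc(Cl)cc3c(=S)n2N)cc1` carries the change (amino in place of hydrogen on an aromatic nitrogen). Among the measured compounds shown here, no measured pair isolates this change, and compound 2 differs from compound 1 in two places, so its number alone cannot show what the amino group does. The expected step is small, toward a higher number, possibly within the scatter, a 1.5-fold higher number from compound 1 to compound 3 (0.19 log units; within the scatter). For compound 3 the estimate in this assay is 7 ug/mL, with a range of 3 ug/mL to 18 ug/mL.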

Compound 3, half-maximal inhibitory concentration: 14 ug/mL
The estimate for compound 3 lay 2.0-fold (0.30 log units) below the measured number; measured number inside the range.
By their numbers in this assay, from the lowest: compound 1; then compounds 2 and 3 (each within the scatter of the next).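

In this assay, among the compounds shown here, amino in place of hydrogen on an aromatic nitrogen gives a 3.1-fold higher number from compound 1 to compound 3 (0.49 log units; beyond the scatter) as a modest weakening, the first clean reading of this change at this position. With the amino group present, compound 2, which carries a carbonyl where compound 3 carries the thione, and compound 3 lie within the scatter of each other. Nothing available explains the step. From the compounds shown here alone, whether a methyl group, a hydroxyl group or a longer chain on this ring nitrogen would weaken the compound to the same extent stays open.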